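A few compounds are considered here, and "the series" means these few. Any claim that something is new, unique, unknown or untested is made for them only; others in the source may bear on it.

Measured so far, in a toxicity assay on MT2 cells (Homo sapiens) for cytotoxicity, read by MTT assay; on this read-out higher numbers stand for lower toxicity in this test and lower numbers for higher toxicity in this test:

Compound 1, `N#Cc1ccc2c(Cl)cc(Oc3ccccc3OCCn3ccc(=O)[nH]c3=O)cc2c1`: 12000 nM
Compound 2, `Cc1cc(Oc2ccccc2OCCn2ccc(=O)[nH]c2=O)cc2cc(C#N)ccc12`: 6000 nM
Compound 3, `Cc1c(Oc2ccccc2OCCn2ccc(=O)[nH]c2=O)cc(Cl)c2ccc(C#N)cc12`: in this assay compound 3 gives only a limit, > 100000 nM.

Compound 1 stands at the higher of the two numbers obtained in this assay; compound 2 is its nearest neighbour, at a 2.0-fold lower number from compound 1 to compound 2 (0.30 log units; within the scatter), so the two cannot be ranked. Compound 3 is known only as a limit, (the limit of > 100000 nM in this assay, at which 1 of the 3 values shown sits).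

Compound 4, `N#Cc1ccc2c(Cl)cc(Oc3ccc(F)cc3OCCn3ccc(=O)[nH]c3=O)cc2c1`, is not yet measured. It differs from compound 1 in one place: fluoro in place of hydrogen on an aromatic carbon. The fluoro enters the six-membered ring of carbon only, meta to a large group and para to a large group.

Neither measured step tests this change. The step from compound 1 to compound 2 exchanges two groups on the shared core, a 2.0-fold lower number from compound 1 to compound 2 (0.30 log units; within the scatter). The step from compound 1 to compound 3 adds a methyl on an aromatic carbon of the core, an at least 8.3-fold higher number from compound 1 to compound 3 (0.92 log units; beyond the scatter), and ends at a limit; it concerns a different ring and a different group, so it carries little over to a fluoro on the ring of carbon only. Within the data shown here, with no step of this kind measured, the expected step in this assay from compound 1 is a 1.3-fold higher number from compound 1 to compound 4 (0.10 log units; within the scatter), none beyond the scatter, with a wide range. Compound 4 is therefore estimated at 15000 nM, expected between 5000 nM and 45000 nM.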

Compound 4, half-maximal cytotoxic concentration: > 100000 nM
Compound 4 gave a limit, no number; the forecaster's own chance of this, stated with the estimate: 15%; middle value at least 6.6-fold (0.82 log units) from the limit.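

In this assay this position, meta to a large group and para to a large group, proves sensitive: fluoro in place of hydrogen on an aromatic carbon gives an at least 8.3-fold higher number from compound 1 to compound 4 (0.92 log units; beyond the scatter) with only one heavy atom entering, a step beyond the scatter towards lower toxicity in this test. The earlier steps shown here, a 2.0-fold lower number from compound 1 to compound 2 (0.30 log units; within the scatter) and an at least 8.3-fold higher number from compound 1 to compound 3 (0.92 log units; beyond the scatter) changed other places on the shared core and gave no reading of this one. Compound 4 is a limit and not a number, so the full size of this step stays unknown, and compound 4 joins the values that stop at a limit: the limit of > 100000 nM in this assay, at which 2 of the 4 values shown sit.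

From the compounds shown here alone, whether the shift belongs to fluoro itself or would follow any group at this position stays open: chloro, methoxy or an amine in the same place would separate the two readings. Also open, going by these compounds, is whether fluoro on the other aromatic carbons of the same ring gives a step of similar size or none beyond the scatter.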